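A few compounds are considered here, and "the series" means these few. Any claim that something is new, unique, unknown or untested is made for them only; others in the source may bear on it.

Compound 1 `Cc1cccc2sc(NC(=O)CCN3CCN(C(C)C)CC3)nc12` in an assay on membranes from brain for displacement of a labelled ligand from Sigma non-opioid intracellular receptor 1 (Cavia porcellus), read by scintillation counting, with a stated time of 120 min (a higher number here means a weaker inhibitor, a lower number a stronger inhibitor), gives 1300 nM.
Compound 2 `Cc1cccc2sc(NC(=O)CCN3CCN(CCN(C(C)C)C(C)C)CC3)nc12` in this assay gives 809 nM.

Within the data shown here, compound 2 has the lowest of the two numbers, but its only neighbour, compound 1, sits within the scatter of it, so the two cannot be told apart. Compound 3 `Cc1cccc2sc(NC(=O)CCN3CCN(c4ccccn4)CC3)nc12` is not yet measured; it differs from compound 2 in one place: pyridin-2-yl in place of 2-(diisopropylamino)ethyl on an amine nitrogen in a ring. Among the measured compounds shown here, the only measured step touches the same ring nitrogen and is a 1.6-fold lower number from compound 1 to compound 2 (0.21 log units; within the scatter), so the one change at this position that has been tried left the number essentially unchanged. For the measured compounds named here, no measured compound carries an aromatic group on this nitrogen, so the size of the coming step cannot be drawn from the data; the expectation is therefore a step of a 1.2-fold higher number from compound 2 to compound 3 (0.09 log units; within the scatter), not beyond the scatter. Compound 3 is estimated to give 1000 nM in this assay, with a range from 250 nM to 4000 nM.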

Compound 3, inhibition constant: 1000 nM
For compound 3 middle estimate and measured number coincide at the digits printed; the range from low to high includes it.
By their numbers in this assay, from the lowest: compounds 2, 3 and 1 (each within the scatter of the next).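

In this assay, pyridin-2-yl in place of 2-(diisopropylamino)ethyl gives a 1.2-fold higher number from compound 2 to compound 3 (0.09 log units; within the scatter), and pyridin-2-yl in place of isopropyl gives a 1.3-fold lower number from compound 1 to compound 3 (0.11 log units; within the scatter). This nitrogen of the six-membered ring now carries an aromatic ring as well as two open-chain groups, yet the three compounds still cannot be told apart, so neither the ring nor the different sizes of these three groups separates them here. No measured evidence explains this result.

As far as these compounds go, it remains open whether any other group on this nitrogen, such as a benzyl group, a phenyl ring or a longer chain ending in a carboxylic acid, would give a step beyond the scatter. Also open, from the compounds shown here alone, is how the number responds to changes in the shared core, or in the chain that joins the core's amide to the six-membered ring.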